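A few compounds are considered here, and "the series" means these few. Any claim that something is new, unique, unknown or untested is made for them only; others in the source may bear on it.

Of the compounds shown here, three sharing one core have been measured in a functional assay on NCI-H460 cells (Homo sapiens) for inhibition, read by MTT assay, with a stated time of 72 h; a higher number here means a weaker inhibitor, a lower number a stronger inhibitor. Compound 1 `CN(C)CCn1c(=O)c(=Cc2ccc(O)cc2)s/c1=C1\C(=O)Nc2ccc(F)cc21` gives 1270 nM in this assay. Compound 2 `CN(C)CCn1c(=O)c(=Cc2ccc(O)cc2)s/c1=C1\C(=O)Nc2ccc(Br)cc21`, which carries bromo in place of fluoro on an aromatic carbon, gives 1110 nM; the step of a 1.1-fold lower number from compound 1 to compound 2 (0.06 log units; within the scatter) lies within the scatter, so this exchange leaves the number essentially unchanged. Compound 3 `CCN(CC)CCCn1c(=O)c(=Cc2cc(OC)c(OC)c(OC)c2)s/c1=C1\C(=O)Nc2ccc(C)cc21`, which differs from the others in several places at once, gives 2670 nM. Among the three numbers compound 1 stands second highest, with compound 2 as its nearest neighbour and compound 3 as its furthest.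

Compound 4 `CN(C)CCn1c(=O)c(=Cc2ccc(F)c(F)c2)s/c1=C1\C(=O)Nc2ccc(F)cc21` has not been measured. It differs from compound 1 in one place: 3,4-difluorophenyl in place of 4-hydroxyphenyl on a double-bonded chain carbon bound to an aromatic carbon. Going by the values given here, no measured step touches this part of the molecule; the only single-point step in the set, between compound 1 and compound 2, concerns the other ring and is within the scatter. There is thus no direct guide, and the change here is of a different kind, as the hydroxyl leaves and fluorines enter. A step beyond the scatter is possible in either direction; a modest rise in the number is expected, a 1.4-fold higher number from compound 1 to compound 4 (0.15 log units; within the scatter). Compound 4 is therefore estimated at 1800 nM, with a range from 700 nM to 4500 nM.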

Compound 4, half-maximal inhibitory concentration: 44700 nM
Compound 4: the middle estimate sits 25-fold (1.40 log units) below what was measured, and the stated range ends below it.
By their numbers in this assay, from the lowest: compounds 2 and 1 (each within the scatter of the next); then compound 3; then compound 4.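

The ring carried on the double-bonded chain carbon turns out to be a sensitive part of the molecule in this assay: replacing 4-hydroxyphenyl with 3,4-difluorophenyl brings a 35-fold higher number from compound 1 to compound 4 (1.55 log units; beyond the scatter) and takes the compound far out of the range of the others. This single change is much larger than the halogen exchange on the other ring, where the printed step is a 1.1-fold lower number from compound 1 to compound 2 (0.06 log units; within the scatter) and the number stays essentially the same, so among these compounds a large effect has been seen only at this position. The swap removes the hydrogen-bond donor and acceptor counted for 4-hydroxyphenyl and adds two fluorines, but nothing measured here explains why the number rises so steeply.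

The compounds shown leave open whether the rise comes from losing the hydroxyl or from gaining the fluorines, since both happen in the same step. An unsubstituted phenyl, a 4-methoxyphenyl or a 4-aminophenyl at this place, on the same core, would help separate the two, and would show how much of the activity of compound 1 depends on the hydroxyl itself.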